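The source may hold more compounds than are shown below. What is called first, only, known or untested is meant among the compounds shown, and "the series" means these compounds.

Compound 1 `OC1CN(C/C=C/I)CCC1N1CCN(c2ccccc2)CC1`: in an assay on PC-12 cells for displacement of a labelled ligand from vesicular acetylcholine transporter (Homo sapiens) (a lower number here means a stronger inhibitor, a higher number a weaker inhibitor), compound 1 reaches only the limit of the assay, > 100 nM.
Compound 2 `OC1CCN(Cc2ccccc2)CC1N1CCN(c2ccccc2)CC1`: in this assay compound 2 likewise reaches only a limit, > 100 nM.

For the measured compounds named here, compound 2 therefore stands with a limit rather than a number, and the same holds for the one other value shown: the limit of > 100 nM in this assay, at which 2 of the 2 values shown sit. Compound 3 `OC1CCN(Cc2ccc(Br)cc2)CC1N1CCN(c2ccccc2)CC1` differs from compound 2 in a single place: bromo in place of hydrogen on an aromatic carbon. No step between measured compounds is available here, so the size of this change cannot be read from any shown step, and the two measured values, both limits, give no direction either. Compound 3 is expected to stay near that limit, with an estimated step that the limit leaves unreadable from compound 2 to compound 3 that is likely no larger than the scatter in either direction. The estimate for compound 3 in this assay is 150 nM, with a range from 30 nM to 1000 nM.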

Compound 3, half-maximal inhibitory concentration: > 100 nM
Compound 3: a limit, no number; the forecaster's own chance of this, stated with the estimate: 60%; the middle value is on the limit's open side.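

For the compounds shown here, compound 3, like compound 2, reaches only a limit, so no step between compound 2 and compound 3 can be read: the limit of > 100 nM in this assay, at which 3 of the 3 values shown sit.
The compounds shown leave open how strongly any of them acts in this assay and whether bromo in place of hydrogen changes that at all.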